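A few compounds are considered here, and "the series" means these few. Any claim that something is new, unique, unknown or untested is made for them only; others in the source may bear on it.

Compound 1 `COc1cc(/C=C/C(=O)/C=C/c2nc3c(C)cccc3n2C)ccc1O` and compound 2 `COc1cc(/C=C/C(=O)/C=C/c2nc3c(C)c(C)ccc3n2C)ccc1O` share one core, and compound 3 `COc1ccc(/C=C/C(=O)/C=C/c2nc3c(C)cccc3n2C)cc1O` and compound 4 `COc1ccc(/C=C/C(=O)/C=C/c2nc3c(C)c(C)ccc3n2C)cc1O` share another; how the two cores differ is not broken down here. In a functional assay on MCF7 cells (Homo sapiens) for cytotoxicity, read by MTT assay, with a stated time of 48 h (on this read-out higher numbers stand for weaker inhibition and lower numbers for stronger inhibition), compound 1 gives 3500 nM, compound 2 gives 14100 nM, and compound 3 gives 7400 nM. Compound 2 carries the change (methyl in place of hydrogen on an aromatic carbon), and this gave a 4.0-fold higher number from compound 1 to compound 2 (0.61 log units; beyond the scatter). Compound 4 carries the same change on its own core, (methyl in place of hydrogen on an aromatic carbon), with the place described in the same words. On the single shown precedent, compound 4 is expected to follow compound 3 with a step of a 3.8-fold higher number from compound 3 to compound 4 (0.58 log units; beyond the scatter) in this assay, resting only on the step from compound 1 to compound 2. Compound 4 is therefore estimated at 28000 nM in this assay, with a likely range from 12000 nM to 70000 nM.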

Compound 4, half-maximal inhibitory concentration: 3500 nM
Estimate against measurement, compound 4: 8.0-fold (0.90 log units) above; measured number below the stated range.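

In this assay, methyl in place of hydrogen on an aromatic carbon did not carry over between the two cores, and its step changed direction: the same change on two cores in this assay, a 4.0-fold higher number (0.61 log units; beyond the scatter) from compound 1 to compound 2 and a 2.1-fold lower number (0.33 log units; beyond the scatter) from compound 3 to compound 4, 8.5-fold (0.93 log units) apart, beyond the scatter of two such steps On the second core the step is a 2.1-fold lower number from compound 3 to compound 4 (0.33 log units; beyond the scatter), while 3-hydroxy-4-methoxyphenyl in place of 4-hydroxy-3-methoxyphenyl gives a 4.0-fold lower number from compound 2 to compound 4 (0.61 log units; beyond the scatter), so the effect of the methyl depends on which of these aryl groups the compound carries. Within the data shown here, with only two pairs, this shows that a step on one core cannot be relied on for the other, but it does not show why, or which direction would be more usual. The compounds shown leave open how an ethyl group, a chlorine atom or an amine on the same aromatic carbon would behave on either core.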